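The compounds below may be only part of what the source reports. "The series", "measured", "known", "first", "only" and "open" are said of these compounds alone.

Series around the core of compound 1 `CCNC(=O)c1noc(-c2cc(C(C)C)c(O)cc2O)c1-c1cc(CO)no1`. Among the compounds with values here, in a functional assay on A2780 cells (Homo sapiens) for inhibition (a lower number here means a stronger inhibitor, a higher number a weaker inhibitor), compound 1 gives 5 nM, the lowest of the three numbers measured so far. Compound 2 `CCNC(=O)c1noc(-c2cc(C(C)C)c(O)cc2O)c1-c1cc(CN(C)C)no1` gives 31 nM, and compound 3 `CCNC(=O)c1noc(-c2cc(C(C)C)c(O)cc2O)c1-c1cc(CN2CCCC2)no1` gives 55 nM. The steps away from compound 1 read a 6.2-fold higher number from compound 1 to compound 2 (0.79 log units; beyond the scatter) and an 11-fold higher number from compound 1 to compound 3 (1.04 log units; beyond the scatter); between the two amines the step is a 1.8-fold higher number from compound 2 to compound 3 (0.25 log units; within the scatter).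

Compound 4 `CCNC(=O)c1noc(-c2cc(C(C)C)c(O)cc2O)c1-c1cc(C(=O)O)no1` is not yet measured. Relative to compound 1 the change is carboxy in place of hydroxymethyl on an aromatic carbon. The measured steps bear on it only loosely: both alter the same group of compound 1, exchanging the hydroxy on the saturated chain carbon for dimethylamino or pyrrolidin-1-yl, whereas here the hydroxymethyl as a whole gives way to carboxy. Both measured steps raised the number beyond the scatter, so changes at this group have so far cost potency; the carboxy, as counted, keeps one hydrogen-bond donor and one acceptor, as the hydroxymethyl does. A step toward a higher number is therefore expected, smaller in size than an 11-fold higher number from compound 1 to compound 3 (1.04 log units; beyond the scatter). For compound 4 the expected step is a 3.0-fold higher number from compound 1 to compound 4 (0.48 log units; beyond the scatter). Compound 4 is estimated to give 15 nM, with a range from 4 nM to 60 nM.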

Compound 4, half-maximal inhibitory concentration: 20000 nM
For compound 4 the middle estimate is 1300-fold (3.12 log units) below the measured one; measured number above the stated range.
By their numbers in this assay, from the lowest: compound 1; then compounds 2 and 3 (each within the scatter of the next); then compound 4.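

At this place on the aromatic ring, next to the ring nitrogen, the two amines had shown only moderate sensitivity in this assay, whereas carboxy in place of hydroxymethyl gives a 4000-fold higher number from compound 1 to compound 4 (3.60 log units; beyond the scatter), a step far larger than either amine step and one that comes with no change in the counted hydrogen-bond donors and acceptors. Compound 4 also stands well apart from both amines, with a 650-fold higher number from compound 2 to compound 4 (2.81 log units; beyond the scatter) and a 360-fold higher number from compound 3 to compound 4 (2.56 log units; beyond the scatter), so the position accepts hydroxymethyl, (dimethylamino)methyl and (pyrrolidin-1-yl)methyl with far smaller losses but not carboxy, and a matched donor and acceptor count does not carry over to a matched result in this pair. Nothing available here accounts for the size of this step.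

Still open, from the compounds shown here alone, is whether the loss belongs to the carboxylic acid itself or extends to other carbonyl groups at this place, which a primary amide or a methyl ester would separate, and whether a carboxymethyl group, with its longer chain, behaves like carboxy. Also open, going by these compounds, is whether a step of this size would appear outside this assay, in a read-out without cells.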